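Swapping the Aryl Group on a Shared Core

This account rests on a few compounds, and the source may have more. Where it says the series, first, only, none or still open, it means among the compounds named here.

Compound 2 `CCC1=C(O)c2c(oc(-c3ccc(C)cc3C)cc2=O)C(CC)(CC)C1=O` gives 8.52 uM in a functional assay on KBVIN cells (Homo sapiens) for antiproliferative activity, read by sulforhodamine B assay, with a stated time of 3 days (a lower number here means that less compound is needed, a higher number that more compound is needed for the effect), the highest of the two numbers measured; compound 1 `CCC1=C(O)c2c(oc(-c3cccc(C)c3)cc2=O)C(CC)(CC)C1=O` gives 3.69 uM in this assay. Within the data shown here, the only measured step, a 2.3-fold higher number from compound 1 to compound 2 (0.36 log units; beyond the scatter), shows that changing the substituents on the aromatic group at this position moves the number modestly. Compound 3 `CCC1=C(O)c2c(oc(-c3ccc(OC)c(Cl)c3)cc2=O)C(CC)(CC)C1=O` carries 3-chloro-4-methoxyphenyl in place of 2,4-dimethylphenyl on an aromatic carbon. Among the measured compounds shown here, no measured step covers a chlorine or methoxy group, so only a modest move in either direction is expected, with compound 3 likely landing between its two neighbours. Compound 3 is estimated at 5 uM, ranging from 2 uM to 12 uM, an expected step of a 1.7-fold lower number from compound 2 to compound 3 (0.23 log units; within the scatter).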

Compound 3, concentration for half-maximal effect: 1.37 uM
Beside the measured number, compound 3's estimate is 3.6-fold (0.56 log units) above it; the measured number lies below the stated range.
By their numbers in this assay, from the lowest: compound 3; then compound 1; then compound 2.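

In this assay, 3-chloro-4-methoxyphenyl on this aromatic carbon gives a 6.2-fold lower number from compound 2 to compound 3 (0.79 log units; beyond the scatter) and also a 2.7-fold lower number from compound 1 to compound 3 (0.43 log units; beyond the scatter), so the aryl group here can take the number below that of either methyl-substituted ring. The earlier compounds shown here showed only a rise on moving to 2,4-dimethylphenyl, whereas this change shows that the position also allows a clear drop, and compound 3 has the lowest number of the three. No evidence at hand bears on the reason for this shift. The chlorine and the methoxy group enter together, and the compounds shown leave open which of them carries the drop. From the compounds shown here alone, how an amine or a carboxylic acid on this aromatic group would read also stays open.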